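A few compounds are considered here, and "the series" means these few. Any claim that something is new, unique, unknown or untested is made for them only; others in the source may bear on it.

The measured compounds:
compound 1 `CC1=C(/C=C/C(=O)/C=C/c2ccc(F)cc2)C(C)(C)CCC1`, which in a functional assay on MCF7 cells (Homo sapiens) for cytotoxicity, read by sulforhodamine B assay, with a stated time of 48 h (on this read-out lower numbers stand for stronger inhibition and higher numbers for weaker inhibition), gives 6200 nM
compound 2 `COc1ccc(/C=C/C(=O)/C=C/C2=C(C)CCCC2(C)C)cc1`, which in this assay gives 19600 nM
compound 3 `CC1=C(/C=C/C(=O)/C=C/c2ccc([N+](=O)[O-])cc2)C(C)(C)CCC1`, which in this assay gives 5500 nM

Compound 1 holds the second highest of the three numbers. Compound 3 is nearest to it, with a 1.1-fold lower number from compound 1 to compound 3 (0.05 log units; within the scatter), and compound 2 is furthest, with a 3.2-fold higher number from compound 1 to compound 2 (0.50 log units; beyond the scatter). Compound 4 `CC1=C(/C=C/C(=O)/C=C/c2ccccc2Br)C(C)(C)CCC1` has not yet been measured. Against compound 1 the change is 2-bromophenyl in place of 4-fluorophenyl on a double-bonded chain carbon bound to a double-bonded chain carbon. The measured steps that bear on this are the exchanges of the group on the aromatic ring of the shared core: a 3.2-fold higher number from compound 1 to compound 2 (0.50 log units; beyond the scatter), a 1.1-fold lower number from compound 1 to compound 3 (0.05 log units; within the scatter) and a 3.6-fold lower number from compound 2 to compound 3 (0.55 log units; beyond the scatter). Going by the values given here, none of them brings in bromine or a 2-substituted ring, so they tell only that such exchanges have moved the number by a modest amount at most here, and in either direction. On that basis no step beyond the scatter is expected. Compound 4 is therefore estimated at about 6500 nM in this assay, within 2500 nM to 17000 nM. The expected step is a 1.0-fold higher number from compound 1 to compound 4 (0.02 log units; within the scatter), which stays within the scatter.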

Compound 4, half-maximal inhibitory concentration: 20700 nM
Compound 4: middle estimate off by 3.2-fold (0.50 log units), on the low side; the whole stated range lies below it.
By their numbers in this assay, from the lowest: compounds 3 and 1 (each within the scatter of the next); then compounds 2 and 4 (each within the scatter of the next).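

The earlier exchanges on the ring had shown a step beyond the scatter only with methoxy, while nitro stayed within it; here, in this assay, 2-bromophenyl in place of 4-fluorophenyl gives a 3.3-fold higher number from compound 1 to compound 4 (0.52 log units; beyond the scatter). So a change on a double-bonded chain carbon bound to a double-bonded chain carbon can raise the number beyond the scatter even when the heavy-atom count and the counts of hydrogen-bond donors and acceptors stay the same. No measurement offered here accounts for this step.

The change swaps the halogen and moves the substituent together, so the compounds shown cannot say which of the two goes with the step. Groups such as 2-fluorophenyl and 4-bromophenyl would separate them, and how a ring bearing an amine or a carboxylic acid would behave remains open.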